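The source may hold more compounds than are shown below. What is called first, only, known or untested is meant among the compounds shown, and "the series" means these compounds.

In a toxicity assay on NIH3T3 cells (Mus musculus) for cytotoxicity, read by resazurin assay (on this read-out higher numbers stand for an effect only at larger amounts of compound and lower numbers for an effect already at smaller amounts), compound 1 `COC(=O)c1ccc(NCc2cncn2Cc2ccc(Cl)cc2)cc1-c1ccccc1` gives 25000 nM as its half-maximal effective concentration. Compound 2 `O=C(c1ccc(NCc2cncn2Cc2ccc(-c3ccccc3)cc2)cc1-c1ccccc1)N1CCCCC1` reads > 1000 nM in this assay and that is only a limit, not a number. Compound 3 `c1ccc(-c2ccc(Cn3cncc3CNc3ccc(-c4cncs4)c(-c4ccccc4)c3)cc2)cc1` carries 1,3-thiazol-5-yl in place of (piperidin-1-yl)carbonyl on an aromatic carbon in comparison with compound 2. Within the data shown here, the only full number is that of compound 1 at 25000 nM and the expectation rests on it. The expected step that the limit leaves unreadable from compound 2 to compound 3 in this assay points toward an effect only at larger amounts, though its size is loosely estimated. Compound 3 is estimated at 10000 nM with 2500 nM to 40000 nM as the expected range.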

Compound 3, half-maximal effective concentration: > 1000 nM
Compound 3 gave a limit, no number; the forecaster's own chance of this, stated with the estimate: 35%; the middle value is on the limit's open side.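

Among these compounds, compound 2 and compound 3 each give only a limit, not a number, so no step between them can be read: the limit of > 1000 nM in this assay, at which 2 of the 3 values shown sit. As far as these compounds go, whether 1,3-thiazol-5-yl in place of (piperidin-1-yl)carbonyl shifts the cytotoxic concentration at all remains open.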